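Methylamino in Place of 4-Chlorophenyl on the Shared Core

The source may hold more compounds than are shown below. What is called first, only, known or untested is meant among the compounds shown, and "the series" means these compounds.

Three compounds were measured in a functional assay on the whole organism for inhibition, with Rattus norvegicus as the target, with a stated time of 3.5 h, at a dose of 100 mg/kg by the intraperitoneal route; on this read-out lower numbers stand for less inhibition and higher numbers for more inhibition at the one dose given (going by the name of the read-out):
compound 1 `Cc1nnc(-c2nsc3ccccc23)o1` gives 42%;
compound 2 `CCc1nnc(-c2nsc3ccccc23)o1` gives 10%;
compound 3 `Clc1ccc(-c2nnc(-c3nsc4ccccc34)o2)cc1` gives 33%.

Compound 3 stands second highest of the three in this assay. Its nearest neighbour is compound 1, a number 9 percentage points lower from compound 1 to compound 3 (within the scatter); its furthest is compound 2, a number 23 percentage points higher from compound 2 to compound 3 (beyond the scatter). Compound 4 `CNc1nnc(-c2nsc3ccccc23)o1` differs from compound 3 in one place: methylamino in place of 4-chlorophenyl on an aromatic carbon. Among the measured compounds shown here, no measured step exchanges a ring for a small nitrogen-bearing group, so the steps that bear on it do so only indirectly. The step of a number 32 percentage points lower from compound 1 to compound 2 (beyond the scatter) shows that a small change at this carbon can move the read-out a long way, while a number 9 percentage points lower from compound 1 to compound 3 (within the scatter) shows that a large change can leave it almost unmoved. The entering methylamino group is a chain of two heavy atoms, as ethyl is, rather than a ring, and compound 1 and compound 2 give widely separated numbers, so the direction is uncertain. Compound 4 is therefore expected to sit a number 8 percentage points lower from compound 3 to compound 4 (within the scatter), with a broad range. The estimate for compound 4 in this assay is 25%, between 5% and 50%.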

Compound 4, a percentage reported as inhibition, in the whole organism at one dose (the size of the read-out at that dose, not a potency): 60%
Estimate against measurement, compound 4: 35 percentage points below; the whole stated range lies below it.
By their numbers in this assay, from the lowest: compound 2; then compounds 3 and 1 (each within the scatter of the next); then compound 4.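

In this assay the exchange at this aromatic carbon gives a number 27 percentage points higher from compound 3 to compound 4 (beyond the scatter) and also a number 18 percentage points higher from compound 1 to compound 4 (beyond the scatter) and further a number 50 percentage points higher from compound 2 to compound 4 (beyond the scatter) in the largest of the three steps. Among the compounds shown here, compound 4 is thus the only compound here that stands clear of all the others, and this position can raise the read-out beyond that of the small methyl group, which the earlier compounds did not show. Ethyl and methylamino are chains of the same heavy-atom count, so that count alone does not set the read-out at this carbon, and nothing shown gives a reason for the rise.

The compounds shown leave open whether the rise follows the nitrogen itself or its hydrogen, which a plain amino, a dimethylamino or a methoxy group could separate. They also leave open whether a longer chain on the nitrogen, such as ethylamino, would keep the rise.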